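Alkyl and cycloalkyl groups on the piperidine nitrogen of a benzamide

This account rests on a few compounds, and the source may have more. Where it says the series, first, only, none or still open, it means among the compounds named here.

Compound 1, `CCCCCCN1CCC(C(=O)Nc2cc(Cl)c(N)cc2OC)CC1`: in a functional assay on the whole organism for antagonist activity, with Mus musculus as the target (on this read-out lower numbers stand for an effect already at smaller amounts and higher numbers for an effect only at larger amounts of compound), compound 1 gives > 10 mg/kg, a limit of the assay.
Compound 2, `CCCCN1CCC(C(=O)Nc2cc(Cl)c(N)cc2OC)CC1`: in this assay compound 2 gives > 10 mg/kg, a limit of the assay.
Compound 3, `COc1cc(N)c(Cl)cc1NC(=O)C1CCN(CC2CCCC2)CC1`: in this assay compound 3 gives > 10 mg/kg, a limit of the assay.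

Compound 3 thus stands at the limit shared by all three measured compounds, as the limit of > 10 mg/kg in this assay, at which 3 of the 3 values shown sit, records. The step to compound 4, `CCCCCN1CCC(C(=O)Nc2cc(Cl)c(N)cc2OC)CC1`, is butyl in place of cyclopentyl on a saturated chain carbon bound to an amine nitrogen in a ring. Of the measured steps, a step that the two limits leave unreadable from compound 1 to compound 3 and a step that the two limits leave unreadable from compound 2 to compound 3 touch the same place, and a step that the two limits leave unreadable from compound 1 to compound 2 the same chain, but none is readable, since all rest on limits. Among the measured compounds shown here, no sized step is therefore available, and the expectation for compound 4 is that it sits with the others. Compound 4 is estimated to give 15 mg/kg in this assay, within 5 mg/kg to 50 mg/kg, which means an expected step that the limit leaves unreadable from compound 3 to compound 4.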

Compound 4, dose for half-maximal effect: > 10 mg/kg
Compound 4 gave a limit, no number (the forecaster's own chance of this, stated with the estimate: 75%); the middle value is on the limit's open side.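

Compound 4, like compound 1, compound 2 and compound 3, gives only a limit, so no step among them can be read in this assay: the limit of > 10 mg/kg in this assay, at which 4 of the 4 values shown sit.

The compounds shown leave open how these groups on the amine nitrogen in a ring would rank on a readable dose.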